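Swapping the aryl group on the amidine carbon of a diphenyl imidazoline

This account rests on a few compounds, and the source may have more. Where it says the series, first, only, none or still open, it means among the compounds named here.

Measured so far:
- compound 1, `Fc1ccc(C2(c3ccc(F)cc3)CNC(c3cccc(Cl)c3)=N2)cc1`: 5.4 nM
- compound 2, `Fc1ccc(C2(c3ccc(F)cc3)CNC(c3cccs3)=N2)cc1`: 54 nM

Both compounds share the same core and differ only in the group attached to the carbon that carries a double bond to nitrogen. In an assay on LM cells for displacement of a labelled ligand from Neuropeptide Y receptor type 5 (Homo sapiens) (a lower number here means a stronger inhibitor, a higher number a weaker inhibitor), compound 1 gives 5.4 nM, while compound 2 gives 54 nM, the higher of the two numbers; the step of a 10-fold higher number from compound 1 to compound 2 (1.00 log units; beyond the scatter) is beyond the scatter, so compound 2 is the weaker binder of the pair.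

Compound 3, `N#Cc1cc(C2=NC(c3ccc(F)cc3)(c3ccc(F)cc3)CN2)ccn1`, has not been measured. It differs from compound 2 in one place: 2-cyanopyridin-4-yl in place of thiophen-2-yl on a carbon with a double bond to nitrogen. For the measured compounds named here, the only measured step that bears on this change is a 10-fold higher number from compound 1 to compound 2 (1.00 log units; beyond the scatter), which shows that exchanging a six-membered aromatic ring for a five-membered one raised the number markedly. Compound 3 returns to a six-membered aromatic ring, though with different substitution, so the expected direction is back toward a lower number. For compound 3 the estimate is 15 nM in this assay, with a range from 3 nM to 80 nM, which would mean a step of a 3.6-fold lower number from compound 2 to compound 3 (0.56 log units; beyond the scatter), expected rather than measured.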

Compound 3, half-maximal inhibitory concentration: 4.8 nM
Compound 3: the middle estimate sits 3.1-fold (0.49 log units) above what was measured, within the range that was stated.
By their numbers in this assay, from the lowest: compounds 3 and 1 (each within the scatter of the next); then compound 2.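

In this assay 2-cyanopyridin-4-yl in place of thiophen-2-yl on the carbon with a double bond to nitrogen gives an 11-fold lower number from compound 2 to compound 3 (1.05 log units; beyond the scatter) and closes the whole gap that thiophen-2-yl had opened against the 3-chlorophenyl group. Set against that group directly, it gives a 1.1-fold lower number from compound 1 to compound 3 (0.05 log units; within the scatter) so two quite different six-membered aromatic rings, one carrying a chlorine and the other a nitrile and a ring nitrogen, cannot be told apart at this position, and a low number here does not depend on the chlorine. Nothing available explains why thiophen-2-yl stands apart from these two groups.

What the compounds shown leave open is whether the ring size or the substituent on the ring matters more, since both groups with low numbers have a six-membered ring and a substituent while thiophen-2-yl has neither; a plain phenyl ring and a thiophen-2-yl ring bearing a chlorine would pull these two apart. From the compounds shown here alone, how far the position's tolerance extends is also open, for example to a ring bearing an amine or a carboxylic acid.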